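Chain swap at the ring nitrogen: compound 2 to compound 4

The compounds below may be only part of what the source reports. "The series", "measured", "known", "first", "only" and "open" are said of these compounds alone.

Three analogues share one core and one trimethoxybenzyl arm. Among the measured compounds shown here, compound 1 `COc1cc(Cc2nc3c(N)ncnc3n2CC2CCCCC2)cc(OC)c1OC` gives 39800 nM in a functional assay on MCF7 cells (Homo sapiens) for antiproliferative activity (on this read-out lower numbers stand for stronger inhibition and higher numbers for weaker inhibition), compound 3 `CCCn1c(Cc2cc(OC)c(OC)c(OC)c2)nc2c(N)ncnc21` gives 46800 nM, and the only one-place step between measured compounds, a 1.2-fold higher number from compound 1 to compound 3 (0.07 log units; within the scatter), stays inside the scatter. Compound 2 `CC[C@H](C)Cn1c(Cc2cc(OC)c(OC)c(OC)c2)nc2c(N)nc(F)nc21` gives 43700 nM and sits with compound 1 and compound 3 inside the scatter, no order among the three being readable. Compound 4 `COCCn1c(Cc2cc(OC)c(OC)c(OC)c2)nc2c(N)nc(F)nc21` carries methoxymethyl in place of sec-butyl on a saturated chain carbon bound to an aromatic nitrogen. For the measured compounds named here, only the step from compound 1 to compound 3 touches this position, and it was flat, so the step of a 1.0-fold higher number from compound 2 to compound 4 (0.01 log units; within the scatter) in this assay is expected to stay within the scatter. Compound 4 is estimated at 45000 nM, with a range from 20000 nM to 110000 nM.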

Compound 4, half-maximal inhibitory concentration: 64600 nM
For compound 4 the middle estimate is 1.4-fold (0.16 log units) below the measured one, within the range that was stated.
By their numbers in this assay, from the lowest: compounds 1, 2, 3 and 4 (each within the scatter of the next).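

In this assay the change to methoxymethyl from sec-butyl gives a 1.5-fold higher number from compound 2 to compound 4 (0.17 log units; within the scatter), so an oxygen-bearing chain with one hydrogen-bond acceptor and no defined stereocentre leaves this position flat, as the all-carbon swap did. This flat reading also extends to the fluorine-bearing core shared by compound 2 and compound 4, whereas the earlier step at this position was on the core without fluorine. No evidence offered here accounts for the result.

On these data alone, whether a primary amine or a carboxylic acid at the end of this chain would move the number beyond the scatter stays open. So does whether a longer ether chain would.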